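Chloro in place of tert-butyl: expectation for compound 4

The source may hold more compounds than are shown below. What is called first, only, known or untested is meant among the compounds shown, and "the series" means these compounds.

The series shares the core of compound 1 `CC(=O)/C=C/c1cccc(C(C)(C)C)c1O`, which in a functional assay for inhibition, with Oryctolagus cuniculus as the target (a higher number here means a weaker inhibitor, a lower number a stronger inhibitor), gives 2190 nM. Compound 2 `CC(=O)/C=C/c1cc(C)ccc1O` gives 8000 nM, and compound 3 `CC(=O)/C=C/c1cc(C(C)(C)C)ccc1O` gives 8000 nM; these two stand level at the digits shown and together give the highest numbers of the three, while compound 1 gives a lower number, beyond the scatter. For the measured compounds named here, the one step measured so far, no change at the digits printed from compound 2 to compound 3 (within the scatter), shows that exchanging methyl for tert-butyl on an aromatic carbon leaves the read-out where it was.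

Compound 4 `CC(=O)/C=C/c1cc(Cl)ccc1O` is the next member and differs from compound 3 by chloro in place of tert-butyl on an aromatic carbon. Going by the values given here, no measured step involves chloro, so the only guide is that the exchange of methyl for tert-butyl on the same aromatic carbon produced no change within the scatter. On that basis the step of no change at the digits printed from compound 3 to compound 4 (within the scatter) is expected to stay within the scatter. Compound 4 is therefore estimated at 8000 nM in this assay, with a range from 3000 nM to 20000 nM.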

Compound 4, half-maximal inhibitory concentration: 60300 nM
For compound 4 the middle estimate is 7.5-fold (0.88 log units) below the measured one; measured number outside the range, above it.
By their numbers in this assay, from the lowest: compound 1; then compounds 2 and 3 (each within the scatter of the next); then compound 4.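

On the aromatic carbon para to a hydroxy group and meta to a 2-acetylethenyl group, the substituent does matter in this assay: chloro gives a 7.5-fold higher number from compound 3 to compound 4 (0.88 log units; beyond the scatter) and, against methyl, a 7.5-fold higher number from compound 2 to compound 4 (0.88 log units; beyond the scatter). The level reading for methyl and tert-butyl therefore does not extend to every group at this position, and compound 4 is the weaker inhibitor in both pairs. No supporting data bear on what lies behind this difference.

As far as these compounds go, whether the higher number is particular to chloro or is shared by other groups at this position, such as fluoro, methoxy, an amine or a carboxylic acid, remains open. The compounds shown also leave open how chloro would read on other aromatic carbons of the shared core.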